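The source may hold more compounds than are shown below. What is called first, only, known or untested is meant among the compounds shown, and "the series" means these compounds.

Compound 1 `COC(=O)N(C)c1c(N)nc(-n2nc(Cc3c(F)ccc(F)c3F)c3ccccc32)nc1N` gives 270 nM in an assay on CHO cells for activation of soluble guanylate cyclase alpha1/beta1 complex (Homo sapiens), read by cGMP accumulation (on this read-out lower numbers stand for an effect already at smaller amounts and higher numbers for an effect only at larger amounts of compound), and compound 2 `COC(=O)N(C)c1c(N)nc(-n2nc(Cc3c(F)ccc(F)c3F)c3cc(Cl)ccc32)nc1N` gives 700 nM; the step of a 2.6-fold higher number from compound 1 to compound 2 (0.41 log units; beyond the scatter) is modest. Compound 3 `CC1(C)C(=O)Nc2nc(-n3nc(CCC(F)(F)F)c4cc(Cl)ccc43)nc(N)c21`, which differs from both in several places, gives 87000 nM, so compound 2 stands second highest of the three, nearest to compound 1 and far from compound 3. Compound 4 `COC(=O)Nc1c(N)nc(-n2nc(Cc3c(F)ccc(F)c3F)c3cc(Cl)ccc32)nc1N` differs from compound 2 by hydrogen in place of methyl on an amide-type nitrogen. Among the compounds with values here, none of the measured steps touches this position: the step from compound 1 to compound 2 concerns a different group, and compound 3 is not a one-place comparison. With no guide, the expected step of no change at the digits printed from compound 2 to compound 4 (within the scatter) is none beyond the scatter. Compound 4 is therefore estimated at 700 nM, within a range from 250 nM to 2000 nM.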

Compound 4, half-maximal effective concentration: 670 nM
The estimate for compound 4 lay 1.0-fold (0.02 log units) above the measured number; low and high end bracket the measured number.
By their numbers in this assay, from the lowest: compound 1; then compounds 4 and 2 (each within the scatter of the next); then compound 3.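

In this assay, the step at this position is a 1.0-fold lower number from compound 2 to compound 4 (0.02 log units; within the scatter), so on the chloro-bearing core of compound 2 the methyl on the amide-type nitrogen can give way to hydrogen with the number staying within the scatter. The earlier compounds shown here gave no reading at this nitrogen. Nothing at hand offers an explanation for this result.

As far as these compounds go, whether an ethyl group or a longer chain on this nitrogen would read the same remains open. So does whether the hydrogen for methyl change reads the same on the core of compound 1, which lacks the chloro.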